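The compounds below may be only part of what the source reports. "The series", "measured", "known", "first", "only" and "open" are said of these compounds alone.

Compound 1 `COc1cc(/C=C/C(=O)OCCCO[N+](=O)[O-])ccc1OCCCO[N+](=O)[O-]`: > 50000 nM (a limit, not a number)
Compound 2 `COc1cc(/C=C/C(=O)OCCCCCO[N+](=O)[O-])ccc1O`: 12300 nM

Among the compounds with values here, in a functional assay on NCI-H460 cells (Homo sapiens) for cytotoxicity, read by resazurin assay, with a stated time of 72 h (a higher number here means a weaker inhibitor, a lower number a stronger inhibitor), compound 2 gives 12300 nM, the only true number so far. Compound 1 is reported only as a limit, > 50000 nM. The next compound to be tested is compound 3 `COc1cc(/C=C/C(=O)OCCCO[N+](=O)[O-])ccc1O`. It keeps the core of compound 2 and changes only the chain, with nitrooxy in place of 2-(nitrooxy)ethyl on a saturated chain carbon, three bonds along the chain from an oxygen next to a carbonyl group. The same difference can be read as 3-(nitrooxy)propyl to (nitrooxy)methyl.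

Within the data shown here, no measured pair isolates this change, so the expectation in this assay is a matter of judgement, anchored on compound 2 at 12300 nM. A modest loss of potency seems most likely, at a size not far beyond the scatter, and a result reported only as a limit cannot be ruled out. The expected change is a 1.6-fold higher number from compound 2 to compound 3 (0.21 log units; within the scatter). For compound 3 the estimated value is 20000 nM, with an expected range from 8000 nM to 50000 nM.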

Compound 3, half-maximal inhibitory concentration: 29000 nM
Compound 3: middle estimate off by 1.5-fold (0.16 log units), on the low side; the range from low to high includes it.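

In this assay, nitrooxy in place of 2-(nitrooxy)ethyl on a saturated chain carbon, three bonds along the chain from an oxygen next to a carbonyl group, gives a 2.4-fold higher number from compound 2 to compound 3 (0.37 log units; beyond the scatter). Within the data shown here, this is the first comparison between two true numbers, and it shows that the length of this chain matters in this assay, with the shorter chain of compound 3 giving the weaker result by a modest step beyond the scatter. At the other place that differs, hydrogen in place of 3-(nitrooxy)propyl on an oxygen on an aromatic ring gives an at least 1.7-fold lower number from compound 1 to compound 3 (0.23 log units; that floor lies within the scatter), so this comparison yields only a floor, and the true size of the step cannot be read, as compound 1 is reported only as a limit: the limit of > 50000 nM in this assay, at which 1 of the 3 values shown sits.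

Two chain lengths cannot show whether a longer chain than that of compound 2 would continue this direction or reverse it. As far as these compounds go, it also remains open whether the nitrooxy group itself is needed, as a compound with a hydroxyl group or an amine in its place on the same chain would show.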